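Carbamate in Place of Amide on a Weak Pyrazoline Inhibitor

The compounds below may be only part of what the source reports. "The series", "measured", "known", "first", "only" and "open" are said of these compounds alone.

The shared core of compound 1 `COc1cc(C2=NNC(c3ccc(Cl)cc3)C2)ccc1O` carries a free amine nitrogen in its ring, and in an assay on isolated protein for inhibition of Amine oxidase [flavin-containing] A (Homo sapiens), read by fluorescence and Amplex Red, with a stated time of 30 min (a lower number here means a stronger inhibitor, a higher number a weaker inhibitor), compound 1 gives 80 nM. Compound 2 `COc1cc(C2=NN(C(=O)c3ccccc3)C(c3ccc(Cl)cc3)C2)ccc1O` places a benzoyl group on that nitrogen, and in this assay compound 2 gives 26200 nM; of the two numbers measured, that of compound 2 is the highest. Within the data shown here, the single measured step, a 330-fold higher number from compound 1 to compound 2 (2.52 log units; beyond the scatter), shows how much the acylation of the ring nitrogen costs.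

Compound 3 `COc1cc(C2=NN(C(=O)Oc3ccccc3)C(c3ccc(Cl)cc3)C2)ccc1O` keeps the carbonyl on the ring nitrogen and differs from compound 2 in one place: phenoxy in place of phenyl on a carbonyl carbon. The step from compound 1 to compound 2 bears on this change only indirectly, since it tells what the carbonyl substituent on the nitrogen does, not what exchanging phenyl for phenoxy on that carbonyl does. Nothing measured separates those two groups. The expectation for compound 3 is therefore a step of a 1.0-fold lower number from compound 2 to compound 3 (0.00 log units; within the scatter), with no change beyond the scatter expected. Compound 3 is estimated at 26000 nM, with a range from 8000 nM to 85000 nM.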

Compound 3, inhibition constant: 193000 nM
Beside the measured number, compound 3's estimate is 7.4-fold (0.87 log units) below it; measured number above the stated range.
By their numbers in this assay, from the lowest: compound 1; then compound 2; then compound 3.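

The result shows that this position on the carbonyl carbon is not indifferent to the exchange of phenyl for phenoxy: in this assay the change gives a 7.4-fold higher number from compound 2 to compound 3 (0.87 log units; beyond the scatter) and so carries the series further from the free amine nitrogen of compound 1. Acylation of the ring nitrogen therefore has no single cost, since the step with the phenoxycarbonyl group, a 2400-fold higher number from compound 1 to compound 3 (3.38 log units; beyond the scatter), exceeds the step with the benzoyl group, a 330-fold higher number from compound 1 to compound 2 (2.52 log units; beyond the scatter), and compound 3 is the weakest inhibitor of the three. Nothing available here accounts for the difference between phenyl and phenoxy on this carbonyl.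

The compounds shown leave open whether the higher number belongs to the phenoxy group in particular or would also appear with a methoxy group or an ethoxy group on the same carbonyl carbon, or with an amine there. They also leave open whether a smaller acyl group on the ring nitrogen, such as acetyl, would stay closer to compound 1 than the benzoyl group of compound 2 does.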